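The compounds below may be only part of what the source reports. "The series", "measured", "known", "first", "only" and "open" are said of these compounds alone.

Compound 2 `CCCCC1([C@H](O)/C=C/C2CCC(=O)[C@@H]2CCCCCC(=O)O)CCC1` was tested in a functional assay on the whole organism (strain Hartley) for inhibition, with Cavia porcellus as the target, with stated times of 15 min and 2 min (on this read-out higher numbers stand for an effect only at larger amounts of compound and lower numbers for an effect already at smaller amounts), where compound 2 gives 0.032 mg/kg. Among the three measured compounds its number is the second highest: compound 1 `CCCCC1([C@@H](O)/C=C/C2[C@H](O)CC(=O)[C@@H]2CCCCCCC(=O)O)CCC1` gives 0.017 mg/kg in this assay, within the scatter of compound 2, while compound 3 `CCCCC1([C@H](O)/C=C/C2CCC(=O)[C@@H]2CCCCCCCCC(=O)OCC)CCC1` gives 6.21 mg/kg, reached by the step of a 190-fold higher number from compound 2 to compound 3 (2.29 log units; beyond the scatter). Compound 4 `CCCCC1([C@H](O)/C=C/C2CCC(=O)[C@@H]2C/C=C\CCCC(=O)O)CCC1` differs from compound 2 by 5-carboxypent-1-en-1-yl in place of 4-carboxybutyl on a saturated chain carbon bound to a saturated ring carbon. Within the data shown here, no measured step adds a double bond to the acid chain; the only measured step alters the acid end itself and is of a different kind. Without a bearing step, compound 4 is expected to stay close to compound 2, with an estimated step of a 1.1-fold lower number from compound 2 to compound 4 (0.03 log units; within the scatter). Compound 4 is estimated at 0.03 mg/kg, between 0.008 mg/kg and 0.12 mg/kg.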

Compound 4, dose for half-maximal effect: 0.0022 mg/kg
Compound 4: the middle estimate sits 14-fold (1.13 log units) above what was measured, outside the stated range (below it).
By their numbers in this assay, from the lowest: compound 4; then compounds 1 and 2 (each within the scatter of the next); then compound 3.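

At this place, on a saturated chain carbon bound to a saturated ring carbon, the acid chain responds strongly to change: in this assay, 5-carboxypent-1-en-1-yl in place of 4-carboxybutyl gives a 15-fold lower number from compound 2 to compound 4 (1.16 log units; beyond the scatter). The earlier step replaced the free acid and raised the number, whereas this one keeps the acid and lowers it. Nothing measured here gives a reason for this.

Going by these compounds, the change adds a chain carbon and a double bond together, so which of the two carries the step stays open. A saturated chain of the same length, or a triple bond in place of the double bond, on the core of compound 2 would separate them.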